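The source may hold more compounds than are shown below. What is called first, only, known or untested is meant among the compounds shown, and "the series" means these compounds.

In a functional assay on SW-620 cells (Homo sapiens) for antiproliferative activity, read by MTT assay, with a stated time of 24 h (on this read-out higher numbers stand for weaker inhibition and lower numbers for stronger inhibition), three compounds that share one core and differ in the group on a double-bonded chain carbon have been measured so far. Compound 1 `COc1ccc(/C=C/C(=O)c2ccc(OC)c3c2OC(C)(C)C=C3)c(F)c1`, carrying 2-fluoro-4-methoxyphenyl, gives 6570 nM. Compound 2 `COc1ccc(C(=O)/C=C/c2ccc(F)cc2)c2c1C=CC(C)(C)O2`, carrying 4-fluorophenyl, reads > 10000 nM, which is a limit of the assay and not a number. Compound 3 `COc1ccc(/C=C/C(=O)c2ccc(OC)c3c2OC(C)(C)C=C3)cn1`, carrying 6-methoxypyridin-3-yl, reads > 10000 nM, which is also a limit. Compound 3 therefore has no exact value and sits at the limit of > 10000 nM in this assay, at which 2 of the 3 values shown sit.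

Compound 4 `COc1ccc(C(=O)/C=C/c2ccco2)c2c1C=CC(C)(C)O2` has furan-2-yl in place of 6-methoxypyridin-3-yl on a double-bonded chain carbon bound to a double-bonded chain carbon. Among the measured compounds shown here, three measured steps bear on this change, since all of them alter the same place. The first is an at least 1.5-fold higher number from compound 1 to compound 2 (0.18 log units; that floor lies within the scatter), the second is an at least 1.5-fold higher number from compound 1 to compound 3 (0.18 log units; that floor lies within the scatter), and the third is a step that the two limits leave unreadable from compound 2 to compound 3. For the measured compounds named here, none of them shows a change beyond the scatter, and no measured compound carries furan-2-yl, so the guidance is thin. The estimated step is a number no higher from compound 3 to compound 4 (the limit leaves the size open), so no change beyond the scatter is expected, and another reading at the limit is the likeliest outcome. For compound 4 the estimate is 10000 nM, with an expected range from 4000 nM to 25000 nM.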

Compound 4, half-maximal inhibitory concentration: > 10000 nM
Compound 4: a limit, no number (the forecaster's own chance of this, stated with the estimate: 65%); the middle value sits exactly at the limit.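

In this assay, compound 4 also gives a limit of the assay and not a number, so a five-membered aromatic ring at this place joins the six-membered rings of compound 2 and compound 3 at the same ceiling: the limit of > 10000 nM in this assay, at which 3 of the 4 values shown sit. Among the compounds shown here, the one step that can be read is an at least 1.5-fold higher number from compound 1 to compound 4 (0.18 log units; that floor lies within the scatter), so this floor alone does not establish a change beyond the scatter, and the steps among compound 2, compound 3 and compound 4 cannot be read, since each of those values is a limit. Across these groups, then, a measurable reading remains confined to the 2-fluoro-4-methoxyphenyl group, as compound 1 gives 6570 nM, and furan-2-yl offers no sign of restoring one.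

The compounds shown leave open how compound 2, compound 3 and compound 4 rank among themselves, since their true values could lie close together or far apart. They also leave open whether a number would return with another group at this place, such as 3,4,5-trimethoxyphenyl or a phenyl ring carrying an amine or a carboxylic acid.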